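This account rests on a few compounds, and the source may have more. Where it says the series, first, only, none or still open, it means among the compounds named here.

In a functional assay on cells (Homo sapiens) for cytotoxicity, read by MTT assay, with a stated time of 24 h (on this read-out lower numbers stand for stronger inhibition and higher numbers for weaker inhibition), compound 1 `CCCCCCCCCCCCCCNC(=O)[C@H](CO)/N=C/c1cccc(OC)c1` gives 31300 nM, compound 2 `CCCCCCCCCCCCCCNC(=O)[C@H](CO)/N=C/c1ccccc1Cl` gives 10300 nM, and compound 3 `CCCCCCCCCCCCCCNC(=O)[C@H](CO)/N=C/c1cccc(Cl)c1` gives 24100 nM. Two measured steps show where compound 3 stands. There is a 1.3-fold lower number from compound 1 to compound 3 (0.11 log units; within the scatter), so these two compounds cannot be told apart, and there is a 2.3-fold higher number from compound 2 to compound 3 (0.37 log units; beyond the scatter), a modest but real gap.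

The next compound is compound 4 `CCCCCCCCCCCCCCNC(=O)[C@H](CO)/N=C/c1ccc(C)cc1`, which brings one change: 4-methylphenyl in place of 3-chlorophenyl on a carbon with a double bond to nitrogen. In words, 4-methylphenyl takes the place of 3-chlorophenyl on a carbon with a double bond to nitrogen. Within the data shown here, no measured compound carries 4-methylphenyl, so the evidence is only indirect. The closest guide is the other swaps at this same place, and the largest of them is modest: a 3.0-fold lower number from compound 1 to compound 2 (0.48 log units; beyond the scatter). Changing the group here has therefore moved the number only a little so far, and the measured steps give no firm direction for this new group. The expected result is a 1.1-fold lower number from compound 3 to compound 4 (0.04 log units; within the scatter), which means no clear change is foreseen. For compound 4 the estimated value is 22000 nM, with an expected range from 10000 nM to 45000 nM.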

Compound 4, half-maximal inhibitory concentration: 102000 nM
Estimate against measurement, compound 4: 4.6-fold (0.67 log units) below; measured number outside the range, above it.
By their numbers in this assay, from the lowest: compound 2; then compounds 3 and 1 (each within the scatter of the next); then compound 4.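

At this place, on a carbon with a double bond to nitrogen, the choice of group matters more than the earlier swaps showed: in this assay there is a 4.2-fold higher number from compound 3 to compound 4 (0.63 log units; beyond the scatter) as well as a 3.3-fold higher number from compound 1 to compound 4 (0.51 log units; beyond the scatter) and also a 9.9-fold higher number from compound 2 to compound 4 (1.00 log units; beyond the scatter), the last being the largest step seen at this place. Compound 4 is therefore the weakest of the four, although 3-chlorophenyl and 4-methylphenyl have the same count of heavy atoms and neither has any hydrogen-bond donors or acceptors, so these counts do not separate them. No measurement here explains why the number rose.

This step changes both the group on the ring and where it sits, so the two effects cannot be separated. As far as these compounds go, how a phenyl carrying an amine or a carboxylic acid would behave at this place also remains open.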